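Removing the Methoxymethyl from a Dibutylamino Carbamate

The source may hold more compounds than are shown below. What is called first, only, known or untested is meant among the compounds shown, and "the series" means these compounds.

Compound 1, `CCCCCCCCCCCCCC[C@H](OCOC)[C@H](CO)NC(=O)OC(C)(C)C`: 54.8%
Compound 2, `CCCCCCCCCCCCCC[C@H](OCOC)[C@H](CN(CCCC)CCCC)NC(=O)OC(C)(C)C`: 56.1%
Compound 3, `CCCCCCCCCCCCCC[C@H](OCOC)[C@H](CN1CCCCC1)NC(=O)OC(C)(C)C`: 43.7%

Of the compounds shown here, three sharing one core have been measured in a functional assay on DLD-1 cells (Homo sapiens) for antiproliferative activity, read by sulforhodamine B assay, with a stated time of 48 h, tested at 10 uM; a higher number here means more inhibition at the concentration tested (going by the name of the read-out), a lower number less inhibition. Compound 2 gives the highest of the three numbers, but its nearest neighbour is compound 1, and the step of a number 1.3 percentage points higher from compound 1 to compound 2 (within the scatter) lies within the scatter, so the two cannot be ordered. Compound 3 sits apart: the step of a number 12.4 percentage points lower from compound 2 to compound 3 (beyond the scatter) and the step of a number 11.1 percentage points lower from compound 1 to compound 3 (beyond the scatter) both lie beyond the scatter, though each is modest.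

Compound 4, `CCCCCCCCCCCCCC[C@H](O)[C@H](CN(CCCC)CCCC)NC(=O)OC(C)(C)C`, has not yet been measured. It differs from compound 2 by hydrogen in place of methoxymethyl on an oxygen on a saturated carbon.

None of the three measured steps touches this site. All of them vary the group on the saturated chain carbon two bonds along the chain from the amide-type nitrogen, while the methoxymethyl is kept in every measured compound. Going by the values given here, there is therefore no measured step that bears directly on the change from compound 2 to compound 4, and the account can only take the number for compound 2 as its starting point.

With nothing to point in either direction, compound 4 is expected to stay close to compound 2, with a step of a number 4.1 percentage points lower from compound 2 to compound 4 (within the scatter) that is not expected to exceed the scatter. The estimate for compound 4 in this assay is 52%, with a range from 36% to 68%.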

Compound 4, a percentage reported as inhibition, at one concentration (the size of the read-out at that concentration, not a potency): 23.4%
Compound 4: the middle estimate sits 28.6 percentage points above what was measured, outside the stated range (below it).
By their numbers in this assay, from the lowest: compound 4; then compound 3; then compounds 1 and 2 (each within the scatter of the next).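

In this assay, the change from methoxymethoxy to hydroxy, made with the dibutylamino group held in place, gives a number 32.7 percentage points lower from compound 2 to compound 4 (beyond the scatter). Going by these compounds alone, this shows that the number depends strongly on what sits on this oxygen, which the earlier compounds could not show, as all of them carry the methoxymethyl. The step is large, whereas the earlier changes on the saturated chain carbon gave only a number 12.4 percentage points lower from compound 2 to compound 3 (beyond the scatter), which is modest, and a number 1.3 percentage points higher from compound 1 to compound 2 (within the scatter), which lies within the scatter, and nothing measured here accounts for the size of the new step.

The compounds shown leave open whether hydrogen in place of methoxymethyl would lower the number to a similar extent with the hydroxy of compound 1 or the piperidin-1-yl of compound 3 on the chain carbon. They also leave open what a methyl ether or an acetate ester on this oxygen would give, and so whether the loss follows the free hydroxy itself or the absence of the methoxymethyl in particular.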